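A few compounds are considered here, and "the series" means these few. Any claim that something is new, unique, unknown or untested is made for them only; others in the source may bear on it.

Within the shared core of compound 3 `O=C(CSc1nc(-c2ccc(Cl)cc2)c(C(=O)O)c(=O)[nH]1)Nn1c(COc2ccc(Cl)cc2Cl)nc2ccccc2c1=O` the 4-chlorophenyl arm gives 61.4% in a functional assay on the whole organism (strain albino) for inhibition, with Rattus norvegicus as the target, read by paw edema, with stated times of 1 h and 2 h, at a dose of 100 mg/kg by the oral route (a lower number here means less inhibition, a higher number more inhibition at the dose given (going by the name of the read-out)), which is within the scatter of compound 1 `N#Cc1c(-c2ccc(O)cc2)nc(SCC(=O)Nn2c(COc3ccc(Cl)cc3Cl)nc3ccccc3c2=O)[nH]c1=O` at 68.4% and of compound 2 `O=C(CSc1nc(-c2ccccc2)c(C(=O)O)c(=O)[nH]1)Nn1c(COc2ccc(Cl)cc2Cl)nc2ccccc2c1=O` at 68.4%. Among the measured compounds shown here, the only single-point step known, a number 7 percentage points lower from compound 2 to compound 3 (within the scatter), shows that a halogen on this ring moves nothing beyond the scatter. Compound 4 `O=C(CSc1nc(-c2ccc(O)cc2)c(C(=O)O)c(=O)[nH]1)Nn1c(COc2ccc(Cl)cc2Cl)nc2ccccc2c1=O` carries hydroxy in place of chloro on an aromatic carbon. Compound 1, which also bears a hydroxyphenyl though with a nitrile in place of the carboxylic acid, gives a number close to the rest. No step beyond the scatter is therefore expected for compound 4, and the estimate is 66% with a range of 56% to 76%. The expected step is a number 4.6 percentage points higher from compound 3 to compound 4 (within the scatter).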

Compound 4, a percentage reported as inhibition, in the whole organism at one dose (the size of the read-out at that dose, not a potency): 38.6%
The estimate for compound 4 lay 27.4 percentage points above the measured number; the measured number lies below the stated range.
By their numbers in this assay, from the lowest: compound 4; then compounds 3, 1 and 2 (each within the scatter of the next).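

In this assay, hydroxy on this ring moves the number beyond the scatter, a number 22.8 percentage points lower from compound 3 to compound 4 (beyond the scatter) and a number 29.8 percentage points lower from compound 2 to compound 4 (beyond the scatter), whereas chloro in place of hydrogen stayed within it. Hydroxy does not bring this loss in every setting: with carboxy in place of cyano the step is a number 29.8 percentage points lower from compound 1 to compound 4 (beyond the scatter), so among these compounds the low number appears only where hydroxy and carboxy occur together. Nothing available explains this.

As far as these compounds go, whether a methoxy or amino group at this place behaves like hydroxy remains open, as does whether a methyl ester in place of the carboxylic acid would restore the number.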